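Trifluoromethoxy for Ethyl on a Quinoline-Free-Named Urea Core

This account rests on a few compounds, and the source may have more. Where it says the series, first, only, none or still open, it means among the compounds named here.

Measured so far:
- compound 1, `CCc1ccc(NC(=O)Nc2cc(C)nc3ccccc23)cc1`: 16000 nM
- compound 2, `COc1ccc(NC(=O)Nc2cc(C)nc3ccccc23)cc1F`: > 25000 nM

Among the compounds with values here, in an ADME assay on HEK293 cells (Homo sapiens) for cytotoxicity, with a stated time of 72 h (on this read-out higher numbers stand for an effect only at larger amounts of compound and lower numbers for an effect already at smaller amounts), compound 1 gives 16000 nM, the only plain number obtained for this series so far. Compound 2 in this assay gives > 25000 nM, which is a limit of the assay rather than a number; (the limit of > 25000 nM in this assay, at which 1 of the 2 values shown sits). Compound 1 therefore stands as the single fixed point, with the other measured compound sitting at that limit.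

Compound 3, `Cc1cc(NC(=O)Nc2ccc(OC(F)(F)F)cc2)c2ccccc2n1`, is not yet measured. It differs from compound 1 in one place: trifluoromethoxy in place of ethyl on an aromatic carbon. Both groups are small, and the shared core of compound 1 is otherwise unchanged.

Within the data shown here, with no measured step between any two compounds, nothing shows how such a change moves this read-out. The step from compound 1 to compound 3 is expected to be small, a 1.3-fold higher number from compound 1 to compound 3 (0.10 log units; within the scatter), leaning toward higher numbers but within the usual scatter. Compound 3 is expected to give about 20000 nM, between 8000 nM and 40000 nM, with a real chance that the assay reports only a limit.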

Compound 3, half-maximal effective concentration: 14000 nM
Estimate against measurement, compound 3: 1.4-fold (0.15 log units) above; the measured number falls inside the stated range.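

The opening step in this series can now be read: in this assay, trifluoromethoxy in place of ethyl on this aromatic carbon gives a 1.1-fold lower number from compound 1 to compound 3 (0.06 log units; within the scatter). At this place on the ring, then, a group with more heavy atoms than ethyl, and with a hydrogen-bond acceptor that ethyl lacks, leaves the read-out within the usual scatter of repeated measurements. Compound 2 gives a limit and not a number, so this plain comparison of two numbers has no counterpart for it: the limit of > 25000 nM in this assay, at which 1 of the 3 values shown sits.

A single pair cannot tell whether this place accepts nearly any group or whether these two simply happen to give similar numbers in this cytotoxicity read-out. An amine, a carboxylic acid or a longer chain such as butyl at the same aromatic carbon could behave quite differently, and the compounds shown give no reading on such groups, nor on how a change to the methyl group on the shared core would move the number.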